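Naphthalen-1-yl in Place of 4-Formylphenyl on a Benzyl Core

The compounds below may be only part of what the source reports. "The series", "measured", "known", "first", "only" and "open" are said of these compounds alone.

Measured compounds in a functional assay on SNB-75 cells (Homo sapiens) for inhibition, read by sulforhodamine B assay, with a stated time of 48 h, tested at 10 uM; a lower number here means less inhibition, a higher number more inhibition at the concentration tested (going by the name of the read-out):
compound 1 `O=Cc1ccc(-c2cn3ccnc3c(-c3ccc4ncn(C5CCCCC5)c4c3)n2)cc1` gives 21.4%
compound 2 `c1ccc2c(-c3cn4ccnc4c(-c4ccc5ncn(C6CCCCC6)c5c4)n3)cccc2c1` gives 16.5%
compound 3 `O=Cc1ccc(-c2cn3ccnc3c(-c3ccc4ncn(Cc5ccccc5)c4c3)n2)cc1` gives 21.4%

Compound 3 and compound 1 share the same substituent on the aromatic carbon and differ only in the group on the aromatic nitrogen, (benzyl in place of cyclohexyl on an aromatic nitrogen); in this assay this gave no change at the digits printed from compound 1 to compound 3 (within the scatter). Compound 4 `c1ccc(Cn2cnc3ccc(-c4nc(-c5cccc6ccccc56)cn5ccnc45)cc32)cc1` has not been measured in this assay. It differs from compound 3 by naphthalen-1-yl in place of 4-formylphenyl on an aromatic carbon. The same change has already been made once, from compound 1 to compound 2, where it is naphthalen-1-yl in place of 4-formylphenyl on an aromatic carbon and the two place descriptions agree word for word; that step gave a number 4.9 percentage points lower from compound 1 to compound 2 (within the scatter). With one prior example, and that one within the scatter, the expected step from compound 3 to compound 4 is estimated at a number 4.9 percentage points lower from compound 3 to compound 4 (within the scatter), resting on the step from compound 1 to compound 2 being a number 4.9 percentage points lower from compound 1 to compound 2 (within the scatter). Compound 4 is therefore expected to give about 16.5% in this assay, likely between 5% and 28%.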

Compound 4, a percentage reported as inhibition, at one concentration (the size of the read-out at that concentration, not a potency): 16.2%
The estimate for compound 4 lay 0.3 percentage points above the measured number; low and high end bracket the measured number.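

In this assay, naphthalen-1-yl in place of 4-formylphenyl on an aromatic carbon gave a number 5.2 percentage points lower from compound 3 to compound 4 (within the scatter), and the cores carrying benzyl and cyclohexyl on the aromatic nitrogen agree on this change: the same change on two cores in this assay, a number 4.9 percentage points lower (within the scatter) from compound 1 to compound 2 and a number 5.2 percentage points lower (within the scatter) from compound 3 to compound 4, 0.3 percentage points apart, within the scatter of two such steps. Likewise, benzyl in place of cyclohexyl on an aromatic nitrogen gave a number 0.3 percentage points lower from compound 2 to compound 4 (within the scatter), and this change agrees across the two groups on the aromatic carbon: the same change on two cores in this assay, no change at the digits printed (within the scatter) from compound 1 to compound 3 and a number 0.3 percentage points lower (within the scatter) from compound 2 to compound 4, 0.3 percentage points apart, within the scatter of two such steps. This shows that both changes carry over between these cores as steps within the scatter, but it does not show that either change truly shifts inhibition, or that the agreement would hold on any other core.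

The compounds shown leave open what a carboxylic acid or an amine in place of the formyl group would give at this site, and whether a longer chain on the aromatic nitrogen would give a step beyond the scatter. The read-out, taken at a single concentration, also gives no potency for any of the four compounds.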